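A Difluorophenyl Isomer in a Narrow Series

The source may report more compounds than this note shows. Statements on the series, on what has been measured and on what is new or still open speak of the compounds shown alone.

Of the compounds shown here, three sharing one core have been measured in a functional assay with Homo sapiens as the target (on this read-out higher numbers stand for weaker inhibition and lower numbers for stronger inhibition), and they differ only in the group on an oxygen on a saturated carbon. With naphthalen-2-yl at that place, compound 1 `CC(C)[C@H](NC(=O)COc1cccc2ccccc12)C(=O)N[C@@H](CC(=O)O)C(=O)COc1ccc2ccccc2c1` gives 15900 nM. With 4-nitrophenyl, compound 2 `CC(C)[C@H](NC(=O)COc1cccc2ccccc12)C(=O)N[C@@H](CC(=O)O)C(=O)COc1ccc([N+](=O)[O-])cc1` gives 22800 nM. With 2,4-difluorophenyl, compound 3 `CC(C)[C@H](NC(=O)COc1cccc2ccccc12)C(=O)N[C@@H](CC(=O)O)C(=O)COc1ccc(F)cc1F` gives 17600 nM, within the scatter of both other compounds.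

The unmeasured compound 4 `CC(C)[C@H](NC(=O)COc1cccc2ccccc12)C(=O)N[C@@H](CC(=O)O)C(=O)COc1ccc(F)c(F)c1` has the same atoms as compound 3, joined differently: 3,4-difluorophenyl in place of 2,4-difluorophenyl on an oxygen on a saturated carbon. In words, 3,4-difluorophenyl stands in place of 2,4-difluorophenyl. Within the data shown here, no measured step compares two difluorophenyl isomers, so the evidence is indirect. Three steps exchange one group for another at this place: a 1.1-fold higher number from compound 1 to compound 3 (0.04 log units; within the scatter), a 1.3-fold lower number from compound 2 to compound 3 (0.11 log units; within the scatter) and a 1.4-fold higher number from compound 1 to compound 2 (0.16 log units; within the scatter). Each lies within the scatter, so no step beyond the scatter is expected in this assay here, and no direction can be favoured. The expected change is a 1.0-fold higher number from compound 3 to compound 4 (0.01 log units; within the scatter). For compound 4 the estimated value is 18000 nM, with an expected range from 9000 nM to 35000 nM.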

Compound 4, half-maximal inhibitory concentration: 16200 nM
Beside the measured number, compound 4's estimate is 1.1-fold (0.05 log units) above it; the measured number falls inside the stated range.
By their numbers in this assay, from the lowest: compounds 1, 4, 3 and 2 (each within the scatter of the next).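

Among these compounds, exchanging 2,4-difluorophenyl for 3,4-difluorophenyl on an oxygen on a saturated carbon gives the first direct comparison of two difluorophenyl isomers: in this assay, the result is a 1.1-fold lower number from compound 3 to compound 4 (0.04 log units; within the scatter). With the same atoms joined differently, this read-out does not separate the two isomers, and the 3,4-difluorophenyl group also stays within the scatter of the other two groups, with a 1.4-fold lower number from compound 2 to compound 4 (0.15 log units; within the scatter) and a 1.0-fold higher number from compound 1 to compound 4 (0.01 log units; within the scatter). Every step among the four compounds shown therefore lies within the scatter, across naphthalen-2-yl, 4-nitrophenyl and both difluorophenyl groups, and nothing measured alongside these numbers offers an explanation for this.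

The compounds shown leave open whether any group at this place can move the number beyond the scatter, for instance an amine, a carboxylic acid or a longer chain in place of the aromatic groups. They also leave open whether the same holds when the shared core carries something other than the present groups, so the flat picture applies only to these four compounds.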